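A few compounds are considered here, and "the series" means these few. Any claim that something is new, unique, unknown or untested is made for them only; others in the source may bear on it.

Measured so far:
- compound 1 `Cc1cc(C)cc(S(=O)(=O)c2c(C(=O)N[C@H]3CCN(S(C)(=O)=O)C3)[nH]c3ccc(Cl)cc23)c1` in an ADME assay on MT4 cells (Homo sapiens) for cytotoxicity, read by MTT assay, with a stated time of 5 days (on this read-out higher numbers stand for lower toxicity in this test and lower numbers for higher toxicity in this test), gives 29900 nM.
- compound 2 `Cc1cc(C)cc(S(=O)(=O)c2c(C(=O)NC3CN(S(C)(=O)=O)C3)[nH]c3ccc(Cl)cc23)c1` in this assay gives only a limit, > 252000 nM.

Compound 2 thus stands at the limit of this assay, with no number. For the measured compounds named here, the one measured step, an at least 8.4-fold higher number from compound 1 to compound 2 (0.92 log units; beyond the scatter), reaches that limit (the limit of > 252000 nM in this assay, at which 1 of the 2 values shown sits). Compound 3 `Cc1cc(C)cc(S(=O)(=O)c2c(C(=O)NS(=O)(=O)c3ccc(F)cc3F)[nH]c3ccc(Cl)cc23)c1` carries (2,4-difluorophenyl)sulfonyl in place of 1-(methylsulfonyl)azetidin-3-yl on an amide-type nitrogen. Going by the values given here, no measured step bears on this change; the only step concerns a different exchange on that nitrogen, so no direction beyond the scatter is expected. Compound 3 is estimated at 100000 nM (range 20000 nM to 300000 nM), the expected step being an at least 2.5-fold lower number from compound 2 to compound 3 (0.40 log units; beyond the scatter).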

Compound 3, half-maximal cytotoxic concentration: 121000 nM
The estimate for compound 3 lay 1.2-fold (0.08 log units) below the measured number; low and high end bracket the measured number.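

In this assay, a group with an aromatic ring, (2,4-difluorophenyl)sulfonyl, on the amide-type nitrogen keeps the read-out within the span set by the two non-aromatic rings, with a 4.0-fold higher number from compound 1 to compound 3 (0.61 log units; beyond the scatter) and an at least 2.0-fold lower number from compound 2 to compound 3 (0.31 log units; beyond the scatter). This shows that the number at this position changes with more than the size of the non-aromatic ring. Compound 2 holds only a limit, so the true size of its step stays unknown: the limit of > 252000 nM in this assay, at which 1 of the 3 values shown sits.

Open remains how phenylsulfonyl without the fluorines, or a group carrying an amine or a carboxylic acid on this nitrogen, would read in this assay.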